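The compounds below may be only part of what the source reports. "The series", "measured", "known", "first", "only" and "open" are said of these compounds alone.

Measured in an ADME assay on a cell-free system (serum, Homo sapiens) for metabolic stability, read by HPLC, with a stated time of 24 h, tested at 150 mM; a lower number here means that the compound disappears faster, a higher number that the compound lasts longer:
Compound 1 `O=C(CI)NCCCN(O)C(=O)/C=C/c1ccc(Cl)cc1Cl`: < 0.5 h, a limit
Compound 2 `O=C(/C=C/c1ccc(Cl)cc1Cl)N(O)CCCN1C(=O)C=CC1=O`: < 0.5 h, a limit

Compound 2 has no number in this assay, only this limit. Compound 3 `O=C(/C=C/c1ccc(Cl)cc1Cl)N(O)CCCCCC1CO1` differs from it by a group of 5 heavy atoms (4 carbon, 1 oxygen; one three-membered non-aromatic ring with 1 hetero atom) in place of a group of 7 heavy atoms (4 carbon, 1 nitrogen, 2 oxygen; one five-membered non-aromatic ring with 1 hetero atom), on a saturated chain carbon, three bonds along the chain from an amide-type nitrogen, with 2-(oxiran-2-yl)ethyl as the entering group. Among the measured compounds shown here, the one measured step, a step that the two limits leave unreadable from compound 1 to compound 2, has no readable size, and the limit of < 0.5 h in this assay, at which 2 of the 2 values shown sit, holds both measured compounds, so neither gives a size to carry over. A readable value could only lie upward of the limit, so a modest, poorly defined rise in this assay is expected, estimated as an at least 2.0-fold higher number from compound 2 to compound 3 (0.30 log units; that floor lies within the scatter). For compound 3 the expected half-life is 1 h, with an estimated range of 0.2 h to 8 h.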

Compound 3, half-life in the Homo sapiens assay: 11 h
Compound 3: the middle estimate sits 11-fold (1.04 log units) below what was measured, and the stated range ends below it.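

In the Homo sapiens assay this saturated chain carbon, three bonds along the chain from an amide-type nitrogen, is no longer held at the limit: 2-(oxiran-2-yl)ethyl gives an at least 22-fold higher number from compound 2 to compound 3 (1.34 log units; beyond the scatter) and an at least 22-fold higher number from compound 1 to compound 3 (1.34 log units; beyond the scatter) with the earlier groups replaced. Both sizes are floors, as each step starts from a limit, yet they show that the half-life responds to the group at this place. In a physicochemical assay for solubility, read by spectrophotometry, with a stated time of 2 h (on this read-out lower numbers stand for lower solubility and higher numbers for higher solubility), compound 2 gives >= 200000 nM, a limit. In the physicochemical assay compound 3 gives >= 200000 nM, also a limit. In the physicochemical assay the step cannot be read, with both compounds at one limit: the limit of >= 200000 nM in the physicochemical assay, at which 2 of the 2 values shown sit.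

Open, as far as these compounds go, is whether the three-membered ring or the chain carries the step, and how an amine or a carboxylic acid at this place would stand in the Homo sapiens assay against compound 3.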